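A few compounds are considered here, and "the series" means these few. Any claim that something is new, unique, unknown or untested is made for them only; others in the source may bear on it.

Compounds measured so far:
compound 1 `CCC[S+]([O-])c1sc2nc(-c3cccs3)cc(C(=O)N(C)C)c2c1N` with 14.7 nM
compound 2 `CCCNC(=O)c1sc2nc(-c3cccs3)cc(-c3ccccc3)c2c1N` with > 7500 nM
compound 3 `CCC[S+]([O-])c1sc2nc(-c3cccs3)cc(C(=O)OCC)c2c1N` with 2 nM

In an assay for inhibition of 15-hydroxyprostaglandin dehydrogenase [NAD(+)] (Homo sapiens), read by fluorescence, with a stated time of 15 min, in the presence of a further agent that is not named here (on this read-out higher numbers stand for weaker inhibition and lower numbers for stronger inhibition), compound 3 gives 2 nM, the lowest of the two numbers shown. Its nearest neighbour is compound 1, which in this assay gives 14.7 nM. For compound 2 the assay reports only a limit, > 7500 nM, not a number; this is the limit described in the limit of > 7500 nM in this assay, at which 1 of the 3 values shown sits.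

The unmeasured compound 4 `CCC[S+]([O-])c1sc2nc(-c3cccs3)cc(-c3ccccc3)c2c1N` differs from compound 3 in one place: phenyl in place of ethoxycarbonyl on an aromatic carbon.

Within the data shown here, only one measured step bears on this position. The change from compound 1 to compound 3 moved the number by a 7.4-fold lower number from compound 1 to compound 3 (0.87 log units; beyond the scatter), so the group on this carbon clearly matters in this assay. Compound 4 removes the carbonyl altogether and puts an aromatic ring there. Among the measured compounds shown here, compound 2, which also carries a phenyl on the shared core, differs from compound 4 elsewhere too, so no single step connects them; its limit only shows that a phenyl-bearing member of this series can fall outside the measurable range.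

Compound 4 is therefore expected to be clearly weaker than compound 3, with an estimated step of a 150-fold higher number from compound 3 to compound 4 (2.18 log units; beyond the scatter). The estimate for compound 4 in this assay is 300 nM, within a range from 30 nM to 3000 nM.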

Compound 4, half-maximal inhibitory concentration: 2.1 nM
Compound 4: the middle estimate sits 140-fold (2.15 log units) above what was measured; the measured number lies below the stated range.
By their numbers in this assay, from the lowest: compounds 3 and 4 (each within the scatter of the next); then compound 1. At a limit, above all of these: compound 2.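

Phenyl in place of ethoxycarbonyl on this aromatic carbon, opposite the ring nitrogen, gives a 1.1-fold higher number from compound 3 to compound 4 (0.02 log units; within the scatter) in this assay, so a carbonyl on this carbon is not required for a low number. Phenyl in place of dimethylcarbamoyl gives a 7.0-fold lower number from compound 1 to compound 4 (0.85 log units; beyond the scatter), which shows that, of the three groups seen on this carbon, dimethylcarbamoyl alone stands beyond the scatter of the other two, and the earlier step from compound 1 to compound 3 was not a matter of ethoxycarbonyl being unique there. With phenyl on this carbon in both compounds, the change on the other aromatic carbon, from the group of 6 heavy atoms to the sulfur-bearing group of 5 heavy atoms, gives an at least 3500-fold lower number from compound 2 to compound 4 (3.55 log units; beyond the scatter), which places the large gap at that other carbon and not at the phenyl, and this step rests on a limit for compound 2: the limit of > 7500 nM in this assay, at which 1 of the 4 values shown sits.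

The compounds shown leave open whether a carboxylic acid, an amine or a substituted phenyl on this carbon would keep the number as low as ethoxycarbonyl and phenyl do. They also leave open how a longer chain on the sulfur would behave with phenyl in place.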